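This account rests on a few compounds, and the source may have more. Where it says the series, first, only, none or still open, it means among the compounds named here.

Compound 1 `O=C1C(Nc2ccc(-c3ccccc3)cc2)=CC(=O)c2ncncc21`, compound 2 `CCc1ccc(-c2ccc(NC3=CC(=O)c4ncncc4C3=O)cc2)cc1` and compound 3 `O=C1C(Nc2ccc(-c3ccc(F)cc3)cc2)=CC(=O)c2ncncc21` share one core and differ only in what they carry on one aromatic carbon. In a functional assay on PANC-1 cells (Homo sapiens) for cytotoxicity, read by MTT assay, with a stated time of 72 h (a lower number here means a stronger inhibitor, a higher number a weaker inhibitor), compound 1 gives 400 nM, compound 2 gives 1200 nM, and compound 3 gives 3200 nM. Compound 3 therefore has the highest number of the three: the step of an 8.0-fold higher number from compound 1 to compound 3 (0.90 log units; beyond the scatter) is the largest among them, the step of a 2.7-fold higher number from compound 2 to compound 3 (0.43 log units; beyond the scatter) is smaller, and the remaining step, a 3.0-fold higher number from compound 1 to compound 2 (0.48 log units; beyond the scatter), also runs upward. Each of these is a single exchange of a small group on an aromatic carbon, and each shifted the number in this assay by a modest amount and beyond the scatter.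

Compound 4 `NS(=O)(=O)c1ccc(NC2=CC(=O)c3ncncc3C2=O)cc1` is not yet measured. It is obtained from compound 3 by the change (sulfamoyl in place of 4-fluorophenyl on an aromatic carbon). Going by the values given here, no measured step matches this: the three known steps only varied a small substituent while the 4-fluorophenyl or phenyl stayed in place, whereas here that whole group leaves and a sulfamoyl enters. What the known steps do show is that this position is sensitive, as the spread from compound 1 to compound 3 indicates, so a change of this size is expected to move the number again, most likely upward. Compound 4 is therefore expected to give 4000 nM, between 1000 nM and 16000 nM, a step of a 1.3-fold higher number from compound 3 to compound 4 (0.10 log units; within the scatter).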

Compound 4, half-maximal inhibitory concentration: > 10000 nM
Compound 4: only a limit was reported; the forecaster's own chance of this, stated with the estimate: 15%; middle value at least 2.5-fold (0.39 log units) away from the limit.
By their numbers in this assay, from the lowest: compound 1; then compound 2; then compound 3. At a limit, above all of these: compound 4.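

In this assay compound 4 stands at a limit and not at a number: the limit of > 10000 nM in this assay, at which 1 of the 4 values shown sits. Compound 1, compound 2 and compound 3 all keep a six-membered aromatic ring of carbon at this place and differ only in what that ring carries, whereas sulfamoyl replaces the whole ring in compound 4, and the number rises in all three comparisons: an at least 3.1-fold higher number from compound 3 to compound 4 (0.49 log units; beyond the scatter), an at least 8.3-fold higher number from compound 2 to compound 4 (0.92 log units; beyond the scatter), and an at least 25-fold higher number from compound 1 to compound 4 (1.39 log units; beyond the scatter). Going by these compounds alone, the step from the unsubstituted phenyl is the only one graded large, so this position tolerates changes on the ring with modest shifts, while this exchange of the ring itself moves the number further than the earlier compounds could show.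

The single change removes the ring and brings in sulfamoyl together, so the compounds shown cannot separate the loss of the one from the arrival of the other, and how far compound 4 lies beyond its limit also stays open. A phenyl carrying the sulfamoyl, or an amine or a carboxylic acid in its place, would be needed to tell these apart.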